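Swapping Diethylamino for Pyrrolidin-1-yl on the Shared Core

This account rests on a few compounds, and the source may have more. Where it says the series, first, only, none or still open, it means among the compounds named here.

In a functional assay on MCF7 cells (Homo sapiens) for antiproliferative activity, read by MTT assay, with a stated time of 48 h (a lower number here means a stronger inhibitor, a higher number a weaker inhibitor), compound 1 `CC(C)=CCC[C@]1(C)/C=C/[C@@H](OC(=O)C=C(C)C)[C@](C)(O)/C=C/C(=O)/C(Cn2cc(CO)nn2)=C\C1` gives 2930 nM and compound 2 `CCN(CC)C(=O)/C1=C/C[C@](C)(CCC=C(C)C)/C=C/[C@@H](OC(=O)C=C(C)C)[C@](C)(O)/C=C/C1=O` gives 12100 nM as the higher of the two numbers. Going by the values given here, the only measured change is a 4.1-fold higher number from compound 1 to compound 2 (0.62 log units; beyond the scatter) and it swaps a different group, which makes it a loose guide at best. Compound 3 `CC(C)=CCC[C@]1(C)/C=C/[C@@H](OC(=O)C=C(C)C)[C@](C)(O)/C=C/C(=O)/C(C(=O)N2CCCC2)=C\C1` carries pyrrolidin-1-yl in place of diethylamino on a carbonyl carbon and otherwise matches compound 2. Among the compounds with values here, no measured step covers this swap, and no step beyond the scatter is expected in this assay here. The estimated change is a 1.2-fold lower number from compound 2 to compound 3 (0.08 log units; within the scatter) at this stage. For compound 3 the expected value is 10000 nM with a range from 4000 nM to 25000 nM in this estimate.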

Compound 3, half-maximal inhibitory concentration: 17200 nM
Beside the measured number, compound 3's estimate is 1.7-fold (0.24 log units) below it, within the range that was stated.
By their numbers in this assay, from the lowest: compound 1; then compounds 2 and 3 (each within the scatter of the next).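

Replacing diethylamino with pyrrolidin-1-yl on a carbonyl carbon adds a ring without changing the heavy-atom count, and in this assay the result is a 1.4-fold higher number from compound 2 to compound 3 (0.15 log units; within the scatter), so this swap does not separate the two amides. Exchanging (4-(hydroxymethyl)-1H-1,2,3-triazol-1-yl)methyl for (pyrrolidin-1-yl)carbonyl gives a 5.9-fold higher number from compound 1 to compound 3 (0.77 log units; beyond the scatter), so a second amide also falls on the weaker side of the triazole group. No measured evidence bears on these results. Still open, going by these compounds, is whether a piperidine amide, a morpholine amide or a carboxylic acid at this carbonyl carbon would read any differently.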